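Replacing a Methyl Group with Trifluoromethyl on the Shared Core

The compounds below may be only part of what the source reports. "The series", "measured", "known", "first", "only" and "open" are said of these compounds alone.

In a functional assay on HeLa cells (Homo sapiens) for cytotoxicity, read by CCK-8 assay, with a stated time of 72 h (on this read-out higher numbers stand for weaker inhibition and lower numbers for stronger inhibition), compound 1 `C=CCn1c(=O)/c(=C\c2cccc(C)c2)[nH]c(=O)/c1=C\c1ccccc1OC` gives 19300 nM. Within the data shown here, compound 2 `C=CCn1c(=O)/c(=C\c2ccccc2F)[nH]c(=O)/c1=C\c1ccccc1OC` gives 45000 nM, and the single measured step is a 2.3-fold higher number from compound 1 to compound 2 (0.37 log units; beyond the scatter). Compound 3 `C=CCn1c(=O)/c(=C\c2ccc(C)cc2)[nH]c(=O)/c1=C\c1ccccc1OC` is recorded as "not active" (no number reported) in this assay, with no number reported, so it can only be placed at the weak end of the series. Compound 4 `C=CCn1c(=O)/c(=C\c2ccccc2C(F)(F)F)[nH]c(=O)/c1=C\c1ccccc1OC` differs from compound 3 by 2-(trifluoromethyl)phenyl in place of 4-methylphenyl on a double-bonded chain carbon bound to an aromatic carbon. Among the measured compounds shown here, the one measured step bears only loosely on this change, since it exchanges 3-methylphenyl for 2-fluorophenyl rather than for a trifluoromethyl-bearing ring, and it pointed toward weaker inhibition. Weak inhibition, near the result of compound 2 or weaker, therefore seems most likely. Compound 4 is expected to give about 50000 nM, within a range from 15000 nM to 200000 nM.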

Compound 4, half-maximal inhibitory concentration: 4600 nM
Compound 4: middle estimate off by 11-fold (1.04 log units), on the high side, and the stated range ends above it.
By their numbers in this assay, from the lowest: compound 4; then compound 1; then compound 2.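

At this double-bonded chain carbon, the group on the aromatic ring can move inhibition strongly in either direction in this assay. Trifluoromethyl in place of fluoro gives a 9.8-fold lower number from compound 2 to compound 4 (0.99 log units; beyond the scatter) and 2-(trifluoromethyl)phenyl in place of 3-methylphenyl gives a 4.2-fold lower number from compound 1 to compound 4 (0.62 log units; beyond the scatter) and so reverses the earlier drift toward weaker inhibition. Nothing available gives a cause for this gain. Going by these compounds, what a ring bearing an amine or a carboxylic acid at this place would give stays open, as does whether trifluoromethyl on another ring carbon would keep the gain.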